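Swapping an amine side chain on a shared aryl sulfamate core

The compounds below may be only part of what the source reports. "The series", "measured", "known", "first", "only" and "open" are said of these compounds alone.

Of the compounds shown here, three that share one core have been tested in an assay on HEK293 cells for inhibition of Steryl-sulfatase (Homo sapiens), tested at 0.1 uM; a higher number here means a stronger effect of the compound at the concentration tested, a lower number a weaker effect. Compound 1 `CN(CCCN1CCCCC1)c1ccc(C(=O)N2CCc3ccc(OS(N)(=O)=O)cc3C2)cc1` gives 17.4%, the highest of the three numbers, although the gap to its nearest neighbour lies within the usual scatter. Compound 2 `NS(=O)(=O)Oc1ccc2c(c1)CN(C(=O)c1ccc(N3CCCCC3)cc1)CC2` gives 11.5%, and compound 3 `CCN(Cc1ccccn1)c1cccc(C(=O)N2CCc3ccc(OS(N)(=O)=O)cc3C2)c1` gives 6.5%, the only one of the three that sits beyond the scatter from compound 1.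

Compound 4 `CC(C)CCN(CCC(C)C)c1ccc(C(=O)N2CCc3ccc(OS(N)(=O)=O)cc3C2)cc1` has not yet been measured. Compared with compound 1, the change is diisopentylamino in place of methyl(3-(piperidin-1-yl)propyl)amino on an aromatic carbon. In the same way, from compound 1 to compound 2 the same methyl(3-(piperidin-1-yl)propyl)amino group was replaced by piperidin-1-yl on the same aromatic carbon, and this produced a number 5.9 percentage points lower from compound 1 to compound 2 (within the scatter). Among the compounds with values here, that is the only measured step that bears on the new compound, and it shows that replacing this particular amino group with a different amine-type group left the read-out essentially unchanged. Within the data shown here, no step tells what the diisopentylamino group itself does, so the expectation stays modest.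

Compound 4 is therefore estimated to give 13%, in the range 3% to 25%, which would amount to an expected step of a number 4.4 percentage points lower from compound 1 to compound 4 (within the scatter) and so to no change beyond the scatter.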

Compound 4, a percentage reported as inhibition, at one concentration (the size of the read-out at that concentration, not a potency): 47%
Beside the measured number, compound 4's estimate is 34 percentage points below it, outside the stated range (above it).
By their numbers in this assay, from the lowest: compounds 3, 2 and 1 (each within the scatter of the next, the first and the last beyond it); then compound 4.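

This carbon, para to a large group, responds strongly to the choice of amine in this assay: diisopentylamino gives a number 29.6 percentage points higher from compound 1 to compound 4 (beyond the scatter) and also a number 35.5 percentage points higher from compound 2 to compound 4 (beyond the scatter), whereas the earlier step at the same carbon, a number 5.9 percentage points lower from compound 1 to compound 2 (within the scatter), stayed within the scatter. The change from compound 1 to compound 4 keeps the count of 11 heavy atoms but removes the ring and one nitrogen, so heavy-atom count alone does not set the read-out in this pair. Nothing measured here explains why diisopentylamino gives the higher number.

On these data alone, it remains open whether the higher number depends on the branched ends of the two chains, on there being two chains, or on their length, which a dipentylamino group with straight chains or an isopentylamino group with a single chain would help to separate. As far as these compounds go, each number is also a read-out at one concentration, so how far these compounds differ in potency remains open as well.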